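This account rests on a few compounds, and the source may have more. Where it says the series, first, only, none or still open, it means among the compounds named here.

Measured in a physicochemical assay, read by spectrophotometry, with a stated time of 15 min; a higher number here means a weaker inhibitor, a lower number a stronger inhibitor:
- compound 1 `O=C(CCCc1nc2ccccc2c(=O)[nH]1)N/N=C/c1cc(O)c(O)c(O)c1`: 45000000 nM
- compound 2 `COc1cc(/C=N/NC(=O)CCCc2nc3ccccc3c(=O)[nH]2)cc(OC)c1OC`: 85000000 nM
- compound 3 `COc1cc(/C=N/NC(=O)CCCc2nc3ccccc3c(=O)[nH]2)ccc1O`: 280000000 nM

Compound 3 has the highest number of the three, which makes it the weakest inhibitor so far. Compound 4 `COc1cc(/C=N/NC(=O)CCCc2nc3ccccc3c(=O)[nH]2)cc(OC)c1O` carries methoxy in place of hydrogen on an aromatic carbon of compound 3, ortho to a hydroxy group (methoxy in place of hydrogen on an aromatic carbon). Within the data shown here, one measured step touches this same aromatic group: a 6.2-fold higher number from compound 1 to compound 3 (0.79 log units; beyond the scatter). Among the measured compounds shown here, that step is modest but beyond the scatter, and no measured step tests this exact swap. With compound 3 at the top of the series at 280000000 nM, a modest fall is expected, and the estimated step is a 1.9-fold lower number from compound 3 to compound 4 (0.27 log units; within the scatter). The estimate for compound 4 is 150000000 nM, within an expected range of 50000000 nM to 400000000 nM.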

Compound 4, half-maximal inhibitory concentration: 225000000 nM
The estimate for compound 4 lay 1.5-fold (0.18 log units) below the measured number; measured number inside the range.
By their numbers in this assay, from the lowest: compounds 1 and 2 (each within the scatter of the next); then compounds 4 and 3 (each within the scatter of the next).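

Methoxy in place of hydrogen on this aromatic carbon, ortho to a hydroxy group, is the first swap here that stays within the scatter in this assay (a 1.2-fold lower number from compound 3 to compound 4 (0.09 log units; within the scatter)). Hydrogen in place of methyl on an oxygen on the same aromatic ring goes beyond the scatter (a 2.6-fold higher number from compound 2 to compound 4 (0.42 log units; beyond the scatter)), so in this pair, capping that oxygen with methyl shows up in the number. No measurement shown gives a reason for either result. Going by these compounds, whether an amine or a carboxylic acid in place of this methoxy would move the number remains open.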